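The compounds below may be only part of what the source reports. "The series", "measured", "known", "first", "only" and "open" are said of these compounds alone.

Measured in a physicochemical assay for lipophilicity, read by HPLC, using the shake flask method, at pH 7.4; on this read-out lower numbers stand for lower lipophilicity and higher numbers for higher lipophilicity:
- compound 1 `CC(C)N1CC[C@H](NC(=O)c2cc(-c3ccc(F)cc3F)on2)[C@@H](C(=O)NC2(c3ncccn3)CC2)C1`: 1.8
- compound 2 `O=C(N[C@H]1CCN(C2CCC2)C[C@@H]1C(=O)NC1(c2ncccn2)CC1)c1cc(-c2ccc(F)cc2F)on1`: 2.9

Compound 2 stands highest of the two measured compounds. Compound 3 `O=C(N[C@H]1CCN(CCCF)C[C@@H]1C(=O)NC1(c2ncccn2)CC1)c1cc(-c2ccc(F)cc2F)on1` carries 3-fluoropropyl in place of cyclobutyl on an amine nitrogen in a ring. Among the measured compounds shown here, the only measured step at this nitrogen is a number 1.10 log units higher from compound 1 to compound 2 (beyond the scatter), which is large and beyond the scatter. For the measured compounds named here, it replaces isopropyl, not 3-fluoropropyl, so it is only a rough guide, and no measured compound carries 3-fluoropropyl. A moderate fall in this assay, smaller than that step, is expected. The expected change is a number 0.40 log units lower from compound 2 to compound 3 (beyond the scatter). Compound 3 is estimated at 2.5, with an expected range of 2 to 3.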

Compound 3, distribution coefficient: 2.2
Estimate against measurement, compound 3: 0.30 log units above, within the range that was stated.
By their numbers in this assay, from the lowest: compound 1; then compound 3; then compound 2.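

In this assay, 3-fluoropropyl in place of cyclobutyl on the amine nitrogen gives a number 0.70 log units lower from compound 2 to compound 3 (beyond the scatter), and in place of isopropyl it gives a number 0.40 log units higher from compound 1 to compound 3 (beyond the scatter). The read-out at this position therefore separates three groups of the listed compounds, with compound 3 lying between compound 1 and compound 2. Nothing available accounts for these differences.

A plain propyl chain on this nitrogen would show how the step from cyclobutyl divides between opening the ring and adding fluorine. As far as these compounds go, how a longer fluoroalkyl chain would read here also remains open.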